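Lengthening the acid chain on the indole nitrogen

A few compounds are considered here, and "the series" means these few. Any claim that something is new, unique, unknown or untested is made for them only; others in the source may bear on it.

Compound 1 `Cc1c(Cl)cccc1CCCCOc1ccc(C#Cc2cccc3c(CCCC(=O)O)c(C)n(CC(=O)O)c23)cc1` is an antagonist tested in a functional assay on HEK293 cells for antagonist activity at cysteinyl leukotriene receptor 2 (Homo sapiens), read by fluorescence and calcium flux, with stated times of 30 min and 1 h (a lower number here means a stronger inhibitor, a higher number a weaker inhibitor), where compound 1 gives 0.88 nM. That is the lowest of the two numbers recorded here. Among the compounds with values here, the other measured compound, compound 2 `Cc1c(F)cccc1CCCCOc1ccc(/C=C/c2cccc3c(CCCC(=O)O)c(C)n(CC(=O)O)c23)cc1`, gives 7.2 nM in this assay; compound 2 differs from compound 1 in more than one place, so the two values show only that compound 1 sits well ahead, beyond the usual scatter.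

Compound 3 `Cc1c(Cl)cccc1CCCCOc1ccc(C#Cc2cccc3c(CCCC(=O)O)c(C)n(CCC(=O)O)c23)cc1` has not yet been measured. It is reached from compound 1 by one change: carboxymethyl in place of carboxy on a saturated chain carbon bound to an aromatic nitrogen. Within the data shown here, no measured pair shows this exact change, so its effect must be judged without a direct precedent. A small loss is expected, so that the step of a 3.4-fold higher number from compound 1 to compound 3 (0.53 log units; beyond the scatter) is estimated to lie at the edge of the scatter rather than well beyond it. Compound 3 is therefore expected to give about 3 nM, most likely within 0.8 nM to 12 nM.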

Compound 3, half-maximal inhibitory concentration: 22 nM
Beside the measured number, compound 3's estimate is 7.3-fold (0.87 log units) below it; measured number outside the range, above it.
By their numbers in this assay, from the lowest: compound 1; then compound 2; then compound 3.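

Replacing carboxy with carboxymethyl on a saturated chain carbon bound to an aromatic nitrogen adds one carbon, yet in this assay it gives a 25-fold higher number from compound 1 to compound 3 (1.40 log units; beyond the scatter), a large step well beyond the scatter. This position is therefore sensitive to the length of the acid chain: the acid group stays, the counts of hydrogen-bond donors and acceptors stay the same, and the only difference is that one carbon. Nothing measured here explains the size of this loss.

Going by these compounds, it remains open whether a still longer acid chain would lose more, or whether an amide or a tetrazole at this position would restore the strength of compound 1. A single step also cannot show whether this change would cost as much on other compounds in the series.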